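The source may report more compounds than this note shows. Statements on the series, on what has been measured and on what is new or still open speak of the compounds shown alone.

The compounds measured so far in an assay on COS-7 cells for inhibition of patatin-like phospholipase domain-containing protein 2 (Mus musculus), tested at 200 uM; a higher number here means more inhibition at the concentration tested (going by the name of the read-out), a lower number less inhibition:
Compound 1, `CCOc1ccc(-c2cccc(C(=O)O)c2)cc1`: 23%
Compound 2, `CCCCOC(=O)c1cccc(-c2ccc(OCC)cc2)c1`: 61%
Compound 3, `CCOc1ccc(-c2cccc(C(=O)N3CCCC3)c2)cc1`: 53%

Compound 3 stands second highest of the three numbers in this assay. Its nearest neighbour is compound 2, with a number 8 percentage points lower from compound 2 to compound 3 (within the scatter), and its furthest is compound 1, with a number 30 percentage points higher from compound 1 to compound 3 (beyond the scatter). The other step among the measured compounds, a number 38 percentage points higher from compound 1 to compound 2 (beyond the scatter), likewise leaves the hydroxy on the carbonyl carbon behind.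

Compound 4, `CCOc1ccc(-c2cccc(NC(=O)N(C)C)c2)cc1`, differs from compound 3 in one place: (dimethylcarbamoyl)amino in place of (pyrrolidin-1-yl)carbonyl on an aromatic carbon. The two steps that end at compound 3 bear on it only indirectly: they show that replacing the hydroxy on the carbonyl carbon by butoxy or pyrrolidin-1-yl gave a higher number, and that the two non-acidic groups sit within the scatter of each other. Going by the values given here, no measured step exchanges the carbonyl group itself for a group in which the ring carbon bears nitrogen, so the size of this step is not anchored by any measured pair. Since compound 4, like compound 3, lacks the hydroxy, a step within the scatter is expected in this assay, a number 6 percentage points lower from compound 3 to compound 4 (within the scatter), leaning slightly downward. Compound 4 is therefore estimated at 47%, within a range from 28% to 66%.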

Compound 4, a percentage reported as inhibition, at one concentration (the size of the read-out at that concentration, not a potency): 68%
Compound 4: middle estimate off by 21 percentage points, on the low side; measured number outside the range, above it.
By their numbers in this assay, from the lowest: compound 1; then compounds 3, 2 and 4 (each within the scatter of the next, the first and the last beyond it).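

In this assay, going by these compounds alone, the change to (dimethylcarbamoyl)amino is the first at this aromatic carbon to attach the substituent through nitrogen rather than through a carbonyl carbon, and it gives a number 15 percentage points higher from compound 3 to compound 4 (beyond the scatter), so the groups lacking the hydroxy are not all equivalent here. The same exchange gives a number 7 percentage points higher from compound 2 to compound 4 (within the scatter) against butoxycarbonyl and a number 45 percentage points higher from compound 1 to compound 4 (beyond the scatter) against carboxy, which places compound 2 within the scatter of both compound 3 and compound 4, while only the latter two separate from each other. Nothing given here accounts for the step from the pyrrolidine-bearing amide to the open-chain group.

The exchange alters several things at once, removing the five-membered ring, adding a hydrogen-bond donor and reversing how the carbonyl is attached, and the compounds shown do not separate these changes. On these data alone, it remains open whether a (pyrrolidin-1-yl)carbonylamino group, a version carrying a methyl on the nitrogen attached to the aromatic carbon, or a simple amine at this place would follow compound 4 or compound 3 in this assay.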